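Replacing the aryl group on the hydrazone carbon of compound 1

This account rests on a few compounds, and the source may have more. Where it says the series, first, only, none or still open, it means among the compounds named here.

Measured compounds:
compound 1 `Cn1c(=O)c(=O)n(C2CCCC2)c2nc(N/N=C/c3ccc(F)c(Cl)c3)ncc21`: 9410 nM
compound 2 `Cn1c(=O)c(=O)n(C2CCCC2)c2nc(N/N=C/c3cccs3)ncc21`: > 100000 nM

In a functional assay on A549 cells (Homo sapiens) for antiproliferative activity, read by MTT assay (on this read-out lower numbers stand for stronger inhibition and higher numbers for weaker inhibition), compound 1 gives 9410 nM. That is the only number shown; the other value is a limit. Compound 2 reaches only a limit of the assay, > 100000 nM, as noted in the limit of > 100000 nM in this assay, at which 1 of the 2 values shown sits. For the measured compounds named here, the one measured step, an at least 10-fold higher number from compound 1 to compound 2 (1.02 log units; beyond the scatter), is large, so changing the aryl group at this position can matter a great deal.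

Compound 3 `Cn1c(=O)c(=O)n(C2CCCC2)c2nc(N/N=C/c3cccc([N+](=O)[O-])c3)ncc21` differs from compound 1 by 3-nitrophenyl in place of 3-chloro-4-fluorophenyl on a carbon with a double bond to nitrogen. Going by the values given here, no measured step bears directly on a nitro group here; the step to compound 2 shows only that a thiophen-2-yl ring in place of the aryl ring weakens activity. For compound 3 the expected step is a 1.7-fold higher number from compound 1 to compound 3 (0.23 log units; within the scatter), with wide uncertainty. Compound 3 is estimated at 16000 nM, within 4000 nM to 70000 nM, in this assay.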

Compound 3, half-maximal inhibitory concentration: 12300 nM
Compound 3: the middle estimate sits 1.3-fold (0.11 log units) above what was measured; the range from low to high includes it.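

In this assay, swapping the halogens for a nitro group at this carbon leaves activity unresolved: a 1.3-fold higher number from compound 1 to compound 3 (0.12 log units; within the scatter), so 3-nitrophenyl and 3-chloro-4-fluorophenyl cannot be told apart here. The chlorine and fluorine atoms are therefore not required for this level of activity, as two phenyl rings with different substituents read alike, while the other comparison, an at least 8.1-fold lower number from compound 2 to compound 3 (0.91 log units; beyond the scatter), separates 3-nitrophenyl from thiophen-2-yl in the same way that compound 1 was separated from compound 2. The size of that step stays open-ended, as the value for compound 2 is a limit: the limit of > 100000 nM in this assay, at which 1 of the 3 values shown sits.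

The compounds shown do not tell whether a phenyl ring carrying an amine or a carboxylic acid would read like compound 1 and compound 3. They also leave open whether the loss belongs to thiophene itself or would recur with a furan ring.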